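This account rests on a few compounds, and the source may have more. Where it says the series, first, only, none or still open, it means among the compounds named here.

Measured compounds in a functional assay on Jurkat cells (Homo sapiens) for antiproliferative activity, read by MTT assay, with a stated time of 72 h; on this read-out higher numbers stand for weaker inhibition and lower numbers for stronger inhibition:
- compound 1 `COc1cc(-n2ncnc2-c2ccc(OC(C)C)cc2)cc(OC)c1OC` gives 650 nM
- compound 3 `COc1cc(-n2ncnc2-c2ccc(C)cc2)cc(OC)c1OC` gives 300 nM
- compound 2 `COc1cc(-c2ncnn2-c2cccc(N)c2)cc(OC)c1OC` gives > 10000 nM, a limit of the assay and not a number

Among the numbers shown, compound 1 and compound 3 carry measured values, and a 2.2-fold lower number from compound 1 to compound 3 (0.34 log units; beyond the scatter) is the only step between measured compounds. Compound 2 stands apart from both: its reading of > 10000 nM is a limit (the limit of > 10000 nM in this assay, at which 1 of the 3 values shown sits), so its position relative to compound 1 and compound 3 is known only as a bound.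

Compound 4 `COc1cc(-c2ncnn2-c2cccc(F)c2)cc(OC)c1OC` differs from compound 2 by fluoro in place of amino on an aromatic carbon. Among the measured compounds shown here, no measured step swaps amino for fluoro; the step from compound 1 to compound 3 concerns a methyl for isopropoxy exchange on different compounds and so does not bear directly on this change. For the measured compounds named here, with compound 2 at the limit and no step to carry over, the step of an at least 1.1-fold lower number from compound 2 to compound 4 (0.04 log units; that floor lies within the scatter) is expected to leave compound 4 near where compound 2 stands. Compound 4 is therefore estimated at 9000 nM, within 2500 nM to 30000 nM, with a fair chance that this assay again reports only a limit.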

Compound 4, half-maximal inhibitory concentration: > 10000 nM
Compound 4: a limit, no number (the forecaster's own chance of this, stated with the estimate: 50%); at least 1.1-fold (0.04 log units) between middle value and limit.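

Compound 2 and compound 4 both read as limits and not as numbers, so no step between them can be read: the limit of > 10000 nM in this assay, at which 2 of the 4 values shown sit.

On these data alone, the size and direction of the change from 3-aminophenyl to 3-fluorophenyl stay open, with neither compound 2 nor compound 4 carrying a number.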